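Working notes: amino added to compound 1

The compounds below may be only part of what the source reports. "The series", "measured", "known", "first", "only" and "open" are said of these compounds alone.

Within the data shown here, in a functional assay on Hep 3B2 cells (Homo sapiens) for cytotoxicity, read by sulforhodamine B assay, with a stated time of 48 h (a higher number here means a weaker inhibitor, a lower number a stronger inhibitor), compound 1 (`CCn1cc(-c2nc3ccccc3[nH]2)c(=O)c2cc(F)c(N3CCNCC3)nc21`) gives 7800 nM and holds the highest of the three numbers so far. Compound 2 (`CCn1cc(-c2nc3ccc(Cl)cc3[nH]2)c(=O)c2cc(F)c(N3CCNCC3)cc21`) gives 2300 nM in the same read-out, and compound 3 (`CCn1cc(-c2nc3ccc([N+](=O)[O-])cc3s2)c(=O)c2cc(F)c(N3CCNC(C)C3)c(F)c21`) gives 1400 nM there. Both lie lower than compound 1 by more than the scatter.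

Compound 4 (`CCn1cc(-c2nc3ccc(N)cc3[nH]2)c(=O)c2cc(F)c(N3CCNCC3)nc21`) keeps the core of compound 1 and takes amino in place of hydrogen on an aromatic carbon, in a six-membered aromatic ring of carbon only (amino in place of hydrogen on an aromatic carbon).

Among the measured compounds shown here, no measured pair differs in one place only, so no direct step guides this change. The expectation leans loosely on compound 2 at 2300 nM and compound 3 at 1400 nM as lower numbers, since both carry a further group that compound 1 lacks, among other differences. In this assay a small step towards a lower number is expected, a 2.0-fold lower number from compound 1 to compound 4 (0.29 log units; within the scatter) by this estimate, about the size of the scatter and possibly no real change at all. Compound 4 is estimated at 4000 nM with a range of 1500 nM to 9000 nM expected.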

Compound 4, half-maximal inhibitory concentration: > 10000 nM
Compound 4 was reported as a limit; the forecaster's own chance of this, stated with the estimate: 8%; at least 2.5-fold (0.39 log units) between middle value and limit.
By their numbers in this assay, from the lowest: compounds 3 and 2 (each within the scatter of the next); then compound 1. At a limit, above all of these: compound 4.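

Compound 4 is reported in this assay only as a limit, > 10000 nM. This gives the series its first step in one place, an at least 1.2-fold higher number from compound 1 to compound 4 (0.10 log units; that floor lies within the scatter), so amino in place of hydrogen on this aromatic carbon of the core of compound 1 brings no lower number, although the floor of the step alone does not separate the two compounds beyond the scatter. The earlier compounds could not show this, as they differ from compound 1 in more than one place, and the true size of the step stays unread here, with the new value a limit: the limit of > 10000 nM in this assay, at which 1 of the 4 values shown sits.

Open, on these data alone, is whether a methoxy group or a carboxylic acid on the same aromatic carbon would leave the number where compound 1 stands or move it in either direction. Also open, as far as these compounds go, is whether amino on this carbon gives the same result on the core of compound 2, which differs from compound 1 in more than this one place.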